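Swapping Ethyl and Methyl on the Imidazole Ring

The source may hold more compounds than are shown below. What is called first, only, known or untested is meant among the compounds shown, and "the series" means these compounds.

Three measured compounds share one core and differ only in a small aromatic ring. In an assay on isolated protein for displacement of a labelled ligand from Gonadotropin-releasing hormone receptor (Homo sapiens) (on this read-out lower numbers stand for stronger inhibition and higher numbers for weaker inhibition), compound 1 `Cc1nc(CN2CCN(c3cccc4[nH]c(-c5ccc(C(C)(C)C)cc5)nc34)CC2)c(C)s1` gives 21 nM. Compound 2 `Cc1nc(CN2CCN(c3cccc4[nH]c(-c5ccc(C(C)(C)C)cc5)nc34)CC2)cn1C` gives 10 nM, and compound 3 `CCc1nc(CN2CCN(c3cccc4[nH]c(-c5ccc(C(C)(C)C)cc5)nc34)CC2)cn1C` gives 18 nM, so compound 3 stands second highest of the three, within the scatter of both neighbours. The step of a 2.1-fold lower number from compound 1 to compound 2 (0.32 log units; beyond the scatter) was modest, while a 1.2-fold lower number from compound 1 to compound 3 (0.07 log units; within the scatter) and a 1.8-fold higher number from compound 2 to compound 3 (0.26 log units; within the scatter) stayed within the scatter. Compound 4 `CCn1cc(CN2CCN(c3cccc4[nH]c(-c5ccc(C(C)(C)C)cc5)nc34)CC2)nc1C` differs from compound 3 by 1-ethyl-2-methyl-1H-imidazol-4-yl in place of 2-ethyl-1-methyl-1H-imidazol-4-yl on a saturated chain carbon bound to an amine nitrogen in a ring. Within the data shown here, since the one step that touches this ring's substituents, a 1.8-fold higher number from compound 2 to compound 3 (0.26 log units; within the scatter), lay within the scatter, the expected step in this assay is no change at the digits printed from compound 3 to compound 4 (within the scatter), meaning nothing beyond the scatter. The estimate for compound 4 is 18 nM, ranging from 8 nM to 40 nM.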

Compound 4, half-maximal inhibitory concentration: 10 nM
Compound 4: middle estimate off by 1.8-fold (0.26 log units), on the high side; the measured number falls inside the stated range.
By their numbers in this assay, from the lowest: compounds 2, 4, 3 and 1 (each within the scatter of the next, the first and the last beyond it).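

Swapping the two groups on the imidazole gives a 1.8-fold lower number from compound 3 to compound 4 (0.26 log units; within the scatter) in this assay, and an ethyl in place of the methyl on the ring nitrogen gives no change at the digits printed from compound 2 to compound 4 (within the scatter), so neither change can be told apart from the scatter. Only the exchange of the ring itself stands out, with a 2.1-fold lower number from compound 1 to compound 4 (0.32 log units; beyond the scatter), matching what compound 2 showed. Nothing measured here explains these numbers. On these data alone, whether a longer chain such as propyl on that ring nitrogen would keep these numbers stays open. So does the effect of an amine or a carboxylic acid there.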